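Swapping Anilino for Naphthyloxy on the Amide Side Chain

The source may hold more compounds than are shown below. What is called first, only, known or untested is meant among the compounds shown, and "the series" means these compounds.

Compound 1 `CC(C)C[C@H](N)c1cc(C(F)(F)F)ccc1N1CCN(C(=O)CNc2ccccc2)CC1` gives 3600 nM in an assay on HEK293 cells for displacement of a labelled ligand from Melanocortin receptor 4 (Homo sapiens) (a lower number here means a stronger inhibitor, a higher number a weaker inhibitor), the highest of the three measured numbers. Compound 2 `CC(C)C[C@H](N)c1cc(C(F)(F)F)ccc1N1CCN(C(=O)CSc2ccc(Cl)cc2Cl)CC1` gives 1500 nM, and compound 3 `Cc1cc(CC(C)C(=O)N2CCN(c3ccc(C(F)(F)F)cc3[C@@H](N)CC(C)C)CC2)ccc1Cl` gives 71 nM, the lowest. Compound 4 `CC(C)C[C@H](N)c1cc(C(F)(F)F)ccc1N1CCN(C(=O)COc2cccc3ccccc23)CC1` differs from compound 1 by (naphthalen-1-yl)oxy in place of anilino on a saturated chain carbon bound to a carbonyl carbon. The closest comparison is the step of a 2.4-fold lower number from compound 1 to compound 2 (0.38 log units; beyond the scatter), where (2,4-dichlorophenyl)sulfanyl replaced anilino at the same place. The step of a 51-fold lower number from compound 1 to compound 3 (1.71 log units; beyond the scatter) was far larger, but it alters more of the chain and so weighs less here. A modest gain in this assay is therefore expected for compound 4, an estimated step of a 2.4-fold lower number from compound 1 to compound 4 (0.38 log units; beyond the scatter). Compound 4 is expected to give about 1500 nM, most likely between 500 nM and 4500 nM.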

Compound 4, inhibition constant: 2600 nM
Beside the measured number, compound 4's estimate is 1.7-fold (0.24 log units) below it; measured number inside the range.
By their numbers in this assay, from the lowest: compound 3; then compounds 2, 4 and 1 (each within the scatter of the next, the first and the last beyond it).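

In this assay the larger (naphthalen-1-yl)oxy group, with its two aromatic rings and no hydrogen-bond donor, gives no change beyond the scatter from anilino (a 1.4-fold lower number from compound 1 to compound 4 (0.14 log units; within the scatter)). It also stays within the scatter of the (2,4-dichlorophenyl)sulfanyl group (a 1.7-fold higher number from compound 2 to compound 4 (0.24 log units; within the scatter)), while the large gap to the side chain of compound 3 remains (a 37-fold higher number from compound 3 to compound 4 (1.56 log units; beyond the scatter)). No evidence on hand explains this result.

From the compounds shown here alone, it remains open whether a single methyl on the saturated chain carbon bound to the carbonyl carbon would narrow that gap. Going by these compounds, a carboxylic acid or an amine at this place also remains untested in these compounds.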